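The source may report more compounds than this note shows. Statements on the series, on what has been measured and on what is new or still open speak of the compounds shown alone.

Compound 1 `N=C(N)c1ccc(/N=N/Nc2cccc(C#Cc3ccccn3)c2)cc1` gives 10400 nM in a functional assay on PC-3 cells (Homo sapiens) for antiproliferative activity, read by WST assay, with a stated time of 72 h; a higher number here means a weaker inhibitor of growth, a lower number a stronger inhibitor of growth
Compound 2 `N=C(N)c1ccc(/N=N/Nc2ccccc2C#Cc2ccccc2)cc1` gives 5300 nM in this assay

Going by the values given here, these two values lie within the usual scatter of each other, so the numbers do not separate compound 1 from compound 2, the only other compound measured so far.

Compound 3 `N=C(N)c1ccc(/N=N/Nc2cccc(C#Cc3ccccc3)c2)cc1` has not yet been measured. It differs from compound 1 in one place: phenyl in place of pyridin-2-yl on a triple-bonded carbon. A six-membered aromatic ring with a hetero atom gives way to a six-membered aromatic ring of carbon only.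

Among the compounds with values here, no measured pair shows this change, so its size cannot be read directly from the data. Within the data shown here, the only guide is that compound 1 at 10400 nM and compound 2 at 5300 nM sit close together, which offers no ground for expecting a large move. The expected change is a 1.6-fold lower number from compound 1 to compound 3 (0.20 log units; within the scatter) and stays within the scatter, leaning slightly toward stronger growth inhibition. For compound 3 the estimated value is 6500 nM with an expected range from 2500 nM to 15000 nM as the estimate stands.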

Compound 3, concentration for 50% growth inhibition: 5800 nM
Beside the measured number, compound 3's estimate is 1.1-fold (0.05 log units) above it; the measured number falls inside the stated range.
By their numbers in this assay, from the lowest: compounds 2, 3 and 1 (each within the scatter of the next).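

Going by these compounds alone, compound 1 and compound 3 differ in one place only, so this pair gives the first direct reading of the ring on the triple-bonded carbon: in this assay, phenyl in place of pyridin-2-yl gives a 1.8-fold lower number from compound 1 to compound 3 (0.25 log units; within the scatter). The swap keeps the ring size and the heavy-atom count but exchanges the ring nitrogen, the hydrogen-bond acceptor counted on pyridin-2-yl, for carbon, and the numbers do not separate the two compounds. For this pair, then, that ring nitrogen makes no measurable difference to growth inhibition, and nothing available explains this result.

From the compounds shown here alone, what a quite different group would do at this place stays open: an amine or a carboxylic acid on the phenyl ring, or a longer chain in place of 2-phenylethynyl, would show whether the number can move beyond the scatter here. Within the data shown here, with only this one pair, it also remains open whether the same swap would read alike on a different core.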